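Working notes: aryl exchange from compound 2 to compound 3

This account rests on a few compounds, and the source may have more. Where it says the series, first, only, none or still open, it means among the compounds named here.

Two compounds of the shared core carry numbers in a functional assay, with a stated time of 150 min; a lower number here means a stronger inhibitor, a higher number a weaker inhibitor. Compound 1 `COc1ccc(-c2nc(NN)n(C)c(=O)c2C#N)cc1` gives 56 ug/mL. Compound 2 `CCOC(=O)c1cnn(-c2nc(-c3ccc(OC)cc3)c(C#N)c(=O)n2C)c1N` gives 79 ug/mL, within the scatter of compound 1, so the two cannot be told apart. For the measured compounds named here, no step between measured compounds has been recorded, so nothing is known about the effect of the change that leads to compound 3 `CCOC(=O)c1cnn(-c2nc(-c3ccccc3O)c(C#N)c(=O)n2C)c1N`. The change is 2-hydroxyphenyl in place of 4-methoxyphenyl on an aromatic carbon. On this footing the step from compound 2 to compound 3 is expected to stay within the scatter, estimated as a 1.1-fold lower number from compound 2 to compound 3 (0.05 log units; within the scatter). Compound 3 is therefore expected near 70 ug/mL, with a range from 30 ug/mL to 160 ug/mL.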

Compound 3, half-maximal inhibitory concentration: 64 ug/mL
For compound 3 the middle estimate is 1.1-fold (0.04 log units) above the measured one; measured number inside the range.
By their numbers in this assay, from the lowest: compounds 1, 3 and 2 (each within the scatter of the next).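

First step read at this aromatic carbon: in this assay, 2-hydroxyphenyl in place of 4-methoxyphenyl gives a 1.2-fold lower number from compound 2 to compound 3 (0.09 log units; within the scatter), so the two aryl groups cannot be told apart here. At this position, a hydrogen-bond donor on the aryl group and a different substitution site on it can therefore be present together without a readable difference. No supporting measurement bears on this result.

For the compounds shown here, the single step does not separate the site on the phenyl ring from the identity of the group. Plain phenyl, or an amine or carboxylic acid on that ring, remains open.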